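Changing the group on the carbonyl of compound 2

The source may report more compounds than this note shows. Statements on the series, on what has been measured and on what is new or still open speak of the compounds shown alone.

Among the compounds with values here, in a functional assay on A549 cells (Homo sapiens) for inhibition, read by sulforhodamine B assay, with a stated time of 72 h (on this read-out lower numbers stand for stronger inhibition and higher numbers for weaker inhibition), compound 2 `CC(C)CNC(=O)c1c(N)sc(-c2ccc(Cl)cc2)c1-c1ccc(Cl)cc1` gives 21000 nM, the highest of the two numbers measured so far. Compound 1 `Nc1sc(-c2ccc(Cl)cc2)c(-c2ccc(Cl)cc2)c1C(=O)N1CCCCC1=O`, which shares its core, gives 1820 nM.

The next structure, compound 3 `CN1CCN(C(=O)c2c(N)sc(-c3ccc(Cl)cc3)c2-c2ccc(Cl)cc2)CC1`, carries 4-methylpiperazin-1-yl in place of isobutylamino on a carbonyl carbon. Within the data shown here, only one measured step bears on this change, and it sits on the same carbonyl carbon: a 12-fold higher number from compound 1 to compound 2 (1.06 log units; beyond the scatter), a large step beyond the scatter. So the group at this place can move the number considerably, and the ring-bearing group of compound 1 gave the lower value. Compound 3 also has a ring there, but a different one, and a single pair is thin support. A moderate move towards a lower number therefore seems likely. The expected step is a 2.6-fold lower number from compound 2 to compound 3 (0.42 log units; beyond the scatter). For compound 3 the estimated value is 8000 nM, within a range of 2000 nM to 30000 nM.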

Compound 3, half-maximal inhibitory concentration: 590 nM
For compound 3 the middle estimate is 14-fold (1.13 log units) above the measured one; measured number below the stated range.
By their numbers in this assay, from the lowest: compound 3; then compound 1; then compound 2.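

With 4-methylpiperazin-1-yl on the carbonyl carbon, this assay gives a 36-fold lower number from compound 2 to compound 3 (1.55 log units; beyond the scatter) and so shows that this place can also yield a much lower number than the isobutylamino group does. The two ring-bearing groups also differ, since replacing 2-oxopiperidin-1-yl gives a 3.1-fold lower number from compound 1 to compound 3 (0.49 log units; beyond the scatter) and a ring at this place therefore does not fix the value by itself. Compound 3 now has the lowest number of the three, but no measurement here explains what drives this result.

The compounds shown leave open which part of 4-methylpiperazin-1-yl matters. A piperidin-1-yl or morpholin-4-yl group on the same carbonyl carbon would test the role of the ring's outer nitrogen, while piperazin-1-yl would test the role of the methyl group.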